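The source may hold more compounds than are shown below. What is called first, only, known or untested is meant among the compounds shown, and "the series" means these compounds.

Working notes on the cinnamoyl series sharing one core.

Compound 1 `O=C(/C=C/c1ccc2c(c1)B(O)OC2)c1cccs1` gives 14200 nM in a functional assay on HCT-116 cells (Homo sapiens) for cytotoxicity, read by MTT assay, with a stated time of 48 h; a higher number here means a weaker inhibitor, a lower number a stronger inhibitor. Compound 2 `O=C(/C=C/c1ccc2c(c1)B(O)OC2)c1cccnc1` gives 20500 nM in this assay, and compound 3 `O=C(/C=C/c1ccc2c(c1)B(O)OC2)c1ccc(Cl)cc1` gives 9300 nM. Compound 3 holds the lowest of the three numbers; its separation from compound 1 is a 1.5-fold lower number from compound 1 to compound 3 (0.18 log units; within the scatter), which does not exceed the scatter, while the step of a 2.2-fold lower number from compound 2 to compound 3 (0.34 log units; beyond the scatter) is a modest one beyond it. The step of a 1.4-fold higher number from compound 1 to compound 2 (0.16 log units; within the scatter) also sits inside the scatter, so the three aryl groups on the carbonyl carbon span only a narrow band of numbers.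

Compound 4 `O=C(/C=C/c1ccc2c(c1)B(O)OC2)c1ccccc1F` is not yet measured. Its change from compound 3 is 2-fluorophenyl in place of 4-chlorophenyl on a carbonyl carbon. Going by the values given here, the steps that bear on it are the aryl swaps at the same carbonyl carbon, a 1.5-fold lower number from compound 1 to compound 3 (0.18 log units; within the scatter) and a 2.2-fold lower number from compound 2 to compound 3 (0.34 log units; beyond the scatter), both small. A step of similar size in this assay is therefore expected, with no firm direction, and the pattern of the three measured values suggests at most a slight move toward a higher number.

Compound 4 is accordingly estimated at 12000 nM, with a plausible range from 5000 nM to 30000 nM. The expected step is a 1.3-fold higher number from compound 3 to compound 4 (0.11 log units; within the scatter).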

Compound 4, half-maximal inhibitory concentration: 4200 nM
Compound 4: middle estimate off by 2.9-fold (0.46 log units), on the high side; measured number below the stated range.
By their numbers in this assay, from the lowest: compound 4; then compounds 3, 1 and 2 (each within the scatter of the next, the first and the last beyond it).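

Going by these compounds alone, at this carbonyl carbon, the aryl group can move the number in this assay beyond the scatter from the best of the earlier compounds: 2-fluorophenyl in place of 4-chlorophenyl gives the step (a 2.2-fold lower number from compound 3 to compound 4 (0.35 log units; beyond the scatter)), whereas compound 3 could not be separated from compound 1 within the scatter. The gain holds against the other two aryl groups as well, with a larger step from the pyridin-3-yl group (a 4.9-fold lower number from compound 2 to compound 4 (0.69 log units; beyond the scatter)) and one from the thiophen-2-yl group (a 3.4-fold lower number from compound 1 to compound 4 (0.53 log units; beyond the scatter)), so compound 4 holds the lowest number of the four and each of its steps lies beyond the scatter. The numbers give these steps only as sizes, and nothing at hand says what lies behind them.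

The step from compound 3 changes the halogen and its ring position together, so 2-chlorophenyl and 4-fluorophenyl would be needed to tell which of the two changes carries the lower number. Also open, from the compounds shown here alone, is whether a group other than a halogen at the same ring position, such as methoxy or an amine, would hold or extend the step, and whether the step would persist on any core other than the shared one.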